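Para-substituent swap on the anilino ring of the shared core

The compounds below may be only part of what the source reports. "The series", "measured", "known", "first", "only" and "open" are said of these compounds alone.

Compound 3 `Cc1cc(Nc2ccc(Br)cc2)nc(SCc2nc3ccccc3[nH]2)n1` is the reference here. In a functional assay on MGC-803 cells (Homo sapiens) for cytotoxicity, read by MTT assay, with a stated time of 72 h (a lower number here means a stronger inhibitor, a higher number a weaker inhibitor), compound 3 gives 26800 nM, the lowest of the two numbers in hand; its nearest neighbour is compound 1 `COc1ccc(Nc2cc(C)nc(SCc3nc4ccccc4[nH]3)n2)cc1`, which gives 51100 nM, so that the step of a 1.9-fold lower number from compound 1 to compound 3 (0.28 log units; within the scatter) is within the scatter. Compound 2 `Cc1cc(N2CCCCC2)nc(SCc2nc3ccccc3[nH]2)n1` gives only a limit in this assay, > 100000 nM; the limit of > 100000 nM in this assay, at which 1 of the 3 values shown sits, is where that value sits. The steps of an at least 1.9-fold higher number from compound 1 to compound 2 (0.29 log units; that floor lies within the scatter) and an at least 3.7-fold lower number from compound 2 to compound 3 (0.57 log units; beyond the scatter) both start or end at that limit.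

Compound 4 `Cc1cc(Nc2ccc(F)cc2)nc(SCc2nc3ccccc3[nH]2)n1` differs from compound 3 in one place: fluoro in place of bromo on an aromatic carbon. Of the measured steps, only the change at the same position bears on it, the methoxy-to-bromo step a 1.9-fold lower number from compound 1 to compound 3 (0.28 log units; within the scatter), which stayed within the scatter. Among the measured compounds shown here, no halogen-to-halogen step exists, so the halogen switch is untested, and the sole comparison at that position gave no step beyond the scatter. On that basis the expected step of a 1.3-fold higher number from compound 3 to compound 4 (0.13 log units; within the scatter) is small, with a slight lean towards a higher number, but within the scatter. Compound 4 is therefore expected to give about 36000 nM in this assay, estimated to lie between 15000 nM and 95000 nM.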

Compound 4, half-maximal inhibitory concentration: 5770 nM
The estimate for compound 4 lay 6.2-fold (0.80 log units) above the measured number, and the stated range ends above it.
By their numbers in this assay, from the lowest: compound 4; then compounds 3 and 1 (each within the scatter of the next). At a limit, above all of these: compound 2.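

Among the compounds shown here, at this position, on an aromatic carbon para to a large group, the substituent does change the number in this assay: a 4.6-fold lower number from compound 3 to compound 4 (0.67 log units; beyond the scatter), the first step here beyond the scatter, whereas the methoxy-to-bromo step stayed within it. The second step at this position is also beyond the scatter, an 8.9-fold lower number from compound 1 to compound 4 (0.95 log units; beyond the scatter), so fluoro stands apart from both methoxy and bromo, and compound 4 now has the lowest number in the series, with its steps to compounds 1 and 3 printed as beyond the scatter and compound 2 reading only against a limit. Compound 2 gives only a limit of the assay, so the replacement of piperidin-1-yl by (4-fluorophenyl)amino reads only as a floor: an at least 17-fold lower number from compound 2 to compound 4 (1.23 log units; beyond the scatter).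

On these data alone, with only fluoro, bromo and methoxy at this position, it stays open whether chloro, a bare hydrogen or trifluoromethyl would follow fluoro or fall back to the level of bromo and methoxy. Nothing shown bears on the cause of the fluoro-for-bromo step.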